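This account rests on a few compounds, and the source may have more. Where it says the series, first, only, none or still open, it means among the compounds named here.

Series notes. In a functional assay on SF-295 cells (Homo sapiens) for cytotoxicity, read by sulforhodamine B assay, with a stated time of 48 h (on this read-out higher numbers stand for weaker inhibition of growth and lower numbers for stronger inhibition of growth), compound 1 `COc1ccc(-c2cs/c(=N\NC(=O)c3ccc(O)cc3)n2-c2ccc(OC)cc2OC)cc1` gives 2820 nM, the lowest of the three numbers in hand. Compound 2 `O=C(c1ccc(O)cc1)n1nc(-c2c(Cl)cccc2Cl)sc1=S` gives 5130 nM in this assay, a number within the scatter of that of compound 1, so the two are not separated. Compound 3 `Cc1ccc(-c2cs/c(=N\NC(=O)c3ccc(O)cc3)n2-c2c(C)cccc2C)cc1` gives 20900 nM in this assay, a number beyond the scatter above that of compound 1.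

Compound 4 `COc1ccc(-n2c(-c3ccc(Cl)cc3)cs/c2=N\NC(=O)c2ccc(O)cc2)c(OC)c1` is not yet measured in this assay. It differs from compound 1 in one place: chloro in place of methoxy on an aromatic carbon. Within the data shown here, no measured pair in this set shows this change, so its size cannot be read from the data; with only three numbers in hand and the change confined to one aryl substituent, the expectation is a step of no more than the scatter, with no clear direction. Compound 4 is therefore expected to sit near compound 1, at an estimated 2800 nM with a range from 900 nM to 8500 nM, which corresponds to an expected step of a 1.0-fold lower number from compound 1 to compound 4 (0.00 log units; within the scatter).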

Compound 4, concentration for 50% growth inhibition: 27500 nM
The estimate for compound 4 lay 9.8-fold (0.99 log units) below the measured number, and the stated range ends below it.
By their numbers in this assay, from the lowest: compounds 1 and 2 (each within the scatter of the next); then compounds 3 and 4 (each within the scatter of the next).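

In this assay, 4-methoxyphenyl to 4-chlorophenyl gives a 9.8-fold higher number from compound 1 to compound 4 (0.99 log units; beyond the scatter). Among these compounds, this is the first step that can be read at a single place, and it shows that this position, para to a large group, is not indifferent to its substituent: with the rest of the structure unchanged, methoxy gives the lower number. It is still a single pair, and nothing in hand explains the step.

Open, going by these compounds, is whether the step reflects the loss of methoxy or the arrival of chloro, which an amine, a hydroxyl group or a fluoro at this same place could help separate. Also open, on these data alone, is whether the change keeps its size when the other aryl substituents on the shared core differ from those of compound 1.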